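Amine swap from compound 2 to compound 3

The source may report more compounds than this note shows. Statements on the series, on what has been measured and on what is new or still open speak of the compounds shown alone.

Values in a functional assay on HL-60 cells (Homo sapiens) for inhibition, with a stated time of 72 h (on this read-out lower numbers stand for stronger inhibition and higher numbers for weaker inhibition), for the series so far
Compound 1 `CN(Cc1ncnc2c1ncn2[C@@H]1O[C@H](CO)[C@@H](O)[C@H]1O)c1ccccc1` gives 4000 nM
Compound 2 `CN(Cc1ccccc1)Cc1ncnc2c1ncn2[C@@H]1O[C@H](CO)[C@@H](O)[C@H]1O` gives 5600 nM
Compound 3 `OC[C@H]1O[C@@H](n2cnc3c(CN4CCCCC4)ncnc32)[C@H](O)[C@@H]1O` is not yet measured

Compound 2 at 5600 nM stands within the scatter of compound 1. The next change is piperidin-1-yl in place of benzyl(methyl)amino on a saturated chain carbon bound to an aromatic carbon and puts piperidin-1-yl in place of benzyl(methyl)amino on a saturated chain carbon bound to an aromatic carbon. For the measured compounds named here, the one measured step (a 1.4-fold higher number from compound 1 to compound 2 (0.15 log units; within the scatter)) also altered the amine and stayed within the scatter. Going by the values given here, no shift beyond the scatter is therefore expected in this assay for compound 3, though no measured compound carries piperidin-1-yl. The estimated change is a 1.1-fold higher number from compound 2 to compound 3 (0.03 log units; within the scatter) in size. Compound 3 is expected at 6000 nM (estimated range 2000 nM to 18000 nM).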

Compound 3, half-maximal inhibitory concentration: 6900 nM
Compound 3: middle estimate off by 1.2-fold (0.06 log units), on the low side, and the stated range covers the measured number.
By their numbers in this assay, from the lowest: compounds 1, 2 and 3 (each within the scatter of the next).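

In this assay, piperidin-1-yl in place of benzyl(methyl)amino gives a 1.2-fold higher number from compound 2 to compound 3 (0.09 log units; within the scatter) and piperidin-1-yl in place of methyl(phenyl)amino gives a 1.7-fold higher number from compound 1 to compound 3 (0.24 log units; within the scatter) on this saturated chain carbon bound to an aromatic carbon. A non-aromatic ring amine therefore sits within the scatter of both amines carrying a six-membered aromatic ring of carbon only. No measurement at hand explains this flat result.

Open, from the compounds shown here alone, is whether a primary amine, morpholin-4-yl or a carboxylic acid at this position would also stay within the scatter. Also open, going by these compounds, is whether any change to the shared core would move the number further than these amine swaps.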